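Moving the trifluoromethyl on the hydrazone aryl ring

A few compounds are considered here, and "the series" means these few. Any claim that something is new, unique, unknown or untested is made for them only; others in the source may bear on it.

Compound 1 `CN(C(=O)NC(=O)c1c(F)cccc1F)c1nc(C(F)(F)F)c(C(=O)N/N=C/c2cccc(C(F)(F)F)c2)s1`: 21.8 ug/mL
Compound 2 `CN(C(=O)NC(=O)c1ccccc1F)c1nc(C(F)(F)F)c(C(=O)N/N=C/c2cc(C(F)(F)F)cc(C(F)(F)F)c2)s1`: 6.16 ug/mL
Compound 3 `CN(C(=O)NC(=O)c1ccccc1F)c1nc(C(F)(F)F)c(C(=O)N/N=C/c2ccccc2C(F)(F)F)s1`: 12.2 ug/mL

In a functional assay on MCF7 cells (Homo sapiens) for inhibition, read by MTT assay, with a stated time of 72 h (a lower number here means a stronger inhibitor, a higher number a weaker inhibitor), compound 3 gives 12.2 ug/mL, and the gaps to compound 1 and to compound 2 both stay within the usual scatter, so no order among the three can be read. Compound 4 `CN(C(=O)NC(=O)c1ccccc1F)c1nc(C(F)(F)F)c(C(=O)N/N=C/c2cccc(C(F)(F)F)c2)s1` differs from compound 3 by 3-(trifluoromethyl)phenyl in place of 2-(trifluoromethyl)phenyl on a carbon with a double bond to nitrogen. Within the data shown here, no pair of measured compounds isolates this change; compound 1 carries the same 3-(trifluoromethyl)phenyl group on a different acyl part and its number sits within the scatter of compound 3. A step of no size beyond the scatter is therefore expected in this assay, in either direction. Compound 4 is expected to give 14 ug/mL, between 6 ug/mL and 32 ug/mL. The expected step is a 1.1-fold higher number from compound 3 to compound 4 (0.06 log units; within the scatter).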

Compound 4, half-maximal inhibitory concentration: 20.5 ug/mL
Estimate against measurement, compound 4: 1.5-fold (0.17 log units) below, and the stated range covers the measured number.
By their numbers in this assay, from the lowest: compounds 2, 3, 4 and 1 (each within the scatter of the next, the first and the last beyond it).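

In this assay, 3-(trifluoromethyl)phenyl in place of 2-(trifluoromethyl)phenyl gives a 1.7-fold higher number from compound 3 to compound 4 (0.23 log units; within the scatter), so this isolated move shows no readable effect. Hydrogen in place of trifluoromethyl on an aromatic carbon gives a 3.3-fold higher number from compound 2 to compound 4 (0.52 log units; beyond the scatter), the only one of these steps beyond the scatter. Hydrogen in place of fluoro on an aromatic carbon gives a 1.1-fold lower number from compound 1 to compound 4 (0.03 log units; within the scatter), so that change on the acyl part also shows no readable effect.

From the compounds shown here alone, whether a methoxy group or a nitrile on the same aryl ring would match the trifluoromethyl step remains open. Nothing available explains any of these steps.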